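Selenium in Place of Sulfur on the Shared Core

The source may hold more compounds than are shown below. What is called first, only, known or untested is meant among the compounds shown, and "the series" means these compounds.

Of the compounds shown here, three have so far been tested in a functional assay on MCF7 cells (Homo sapiens) for cytotoxicity, read by MTT assay, with a stated time of 72 h; a lower number here means a stronger inhibitor of growth, a higher number a weaker inhibitor of growth. Compound 1 `COc1ccc(CNc2nc([SeH])nc3ccccc23)cc1` gives 94000 nM. Compound 2 `Sc1nc(NCc2ccccc2)c2ccccc2n1` reaches only a limit of the assay, > 100000 nM. Compound 3 `CSc1nc(NCc2ccc([Se]C)cc2)c2ccccc2n1` likewise stops at a limit, > 100000 nM. Compound 2 thus stands at the limit of > 100000 nM in this assay, at which 2 of the 3 values shown sit, with no number of its own. Compound 4 `[SeH]c1nc(NCc2ccccc2)c2ccccc2n1` differs from compound 2 by a single change: one selenium atom in place of one sulfur atom, on an aromatic carbon. For the measured compounds named here, no step between two measured compounds covers this change. Compound 1, which carries the same selenium atom on the same core and gives 94000 nM, shows that such a compound can return a number near the edge of the measured range. The expected step is therefore small, within the scatter or at most a slight gain in growth inhibition, a number no higher from compound 2 to compound 4 (the limit leaves the size open). Compound 4 is accordingly expected to give about 100000 nM, between 50000 nM and 200000 nM, with a real chance that only a limit is reported.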

Compound 4, concentration for total growth inhibition: > 100000 nM
Compound 4 ended at the assay's limit (the forecaster's own chance of this, stated with the estimate: 50%); the middle value lies on the limit itself.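

In this assay one selenium atom in place of one sulfur atom, on this aromatic carbon between two ring nitrogen atoms, does not bring a measured number: compound 4 stops at a limit, > 100000 nM. Both ends of this change are limits, so its step cannot be read. Hydrogen in place of methoxy on an aromatic carbon gives an at least 1.0-fold higher number from compound 1 to compound 4 (0.02 log units; that floor lies within the scatter), and since that floor lies within the scatter, the methoxy group is not shown to make a difference.

As far as these compounds go, whether selenium differs from sulfur at this position stays open, as most values now sit at one ceiling: the limit of > 100000 nM in this assay, at which 3 of the 4 values shown sit. Also open, from the compounds shown here alone, is whether another group in place of the selenium atom, such as an amine or a carboxylic acid, would give a number well inside the measured range.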